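The source may hold more compounds than are shown below. What is called first, only, known or untested is meant among the compounds shown, and "the series" means these compounds.

Compound 1 `Nc1ncnc2c1c(-c1cc(C3CC3)on1)nn2C1CCCCC1` and compound 2 `CCc1cc(-c2nn(C(C)C)c3ncnc(N)c23)no1` form the measured pair. In an assay on BaF3 cells for inhibition of proto-oncogene tyrosine-protein kinase receptor Ret variant V804M (Homo sapiens), read by MTT assay, with a stated time of 48 h (a lower number here means a stronger inhibitor of growth, a higher number a weaker inhibitor of growth), compound 1 gives 2000 nM. In this assay compound 2 gives 5770 nM, the highest of the two numbers, and the gap to compound 1 lies beyond the usual scatter. Compound 3 `CC(C)c1cc(-c2nn(C(C)C)c3ncnc(N)c23)no1` has not been measured; it differs from compound 2 by methyl in place of hydrogen on a saturated chain carbon bound to an aromatic carbon and a saturated chain carbon. For the measured compounds named here, no step between measured compounds is available, so any expectation rests on the two values alone. The step expected from compound 2 to compound 3 is a modest drop, a 1.8-fold lower number from compound 2 to compound 3 (0.26 log units; within the scatter). Compound 3 is estimated at 3200 nM, within a range of 1200 nM to 8500 nM.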

Compound 3, concentration for 50% growth inhibition: 5900 nM
Beside the measured number, compound 3's estimate is 1.8-fold (0.27 log units) below it; measured number inside the range.
By their numbers in this assay, from the lowest: compound 1; then compounds 2 and 3 (each within the scatter of the next).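

In this assay the exchange of ethyl for isopropyl gives the first step read directly at this position, a 1.0-fold higher number from compound 2 to compound 3 (0.01 log units; within the scatter), so compound 2 and compound 3 cannot be told apart. At this saturated chain carbon, the added methyl therefore produces no step beyond the scatter. Nothing measured on these compounds speaks to the reason for this result. From the compounds shown here alone, whether a hydroxyl group, an amine or a longer chain at this place would separate from compound 2 remains open. So does whether the same exchange would read alike in another part of the series.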